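Carbonyl substituent changes in a naphthylamine imidazole series

The source may report more compounds than this note shows. Statements on the series, on what has been measured and on what is new or still open speak of the compounds shown alone.

Measured so far:
compound 1 `CCCCOC(=O)C(C)(C)C(c1ccc(Nc2ccc3ccccc3c2)cc1)n1ccnc1` — 200 nM
compound 2 `CCCCCOC(=O)C(C)(C)C(c1ccc(Nc2ccc3ccccc3c2)cc1)n1ccnc1` — 140 nM
compound 3 `CC(C)OC(=O)C(C)(C)C(c1ccc(Nc2ccc3ccccc3c2)cc1)n1ccnc1` — 290 nM

All three share one core and differ only in the chain on the oxygen next to a carbonyl group. In an assay on isolated protein for inhibition of cytochrome P450 26A1 (Homo sapiens), read by scintillation counting (a lower number here means a stronger inhibitor, a higher number a weaker inhibitor), compound 3 gives the highest of the three numbers; its gap to compound 1 stays within the scatter, while the gap to compound 2 is modest, as seen in a 2.1-fold higher number from compound 2 to compound 3 (0.32 log units; beyond the scatter). The other measured steps are a 1.4-fold lower number from compound 1 to compound 2 (0.15 log units; within the scatter) and a 1.5-fold higher number from compound 1 to compound 3 (0.16 log units; within the scatter). Taken together, lengthening or branching this chain moved the number only slightly.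

Compound 4 `CNC(=O)C(C)(C)C(c1ccc(Nc2ccc3ccccc3c2)cc1)n1ccnc1` takes a different kind of step: methylamino in place of isopropoxy on a carbonyl carbon. Among the compounds with values here, none of the measured steps changes the atom attached to the carbonyl carbon; they only reshape the chain beyond the oxygen, so they bear on this step only in showing that the region tolerates small alterations without large movement in this assay. Within the data shown here, with no direct precedent, a modest shift in either direction is plausible, and a small rise in the number is taken as the central expectation. Compound 4 is thus expected near 500 nM, within 150 nM to 1700 nM, corresponding to an estimated step of a 1.7-fold higher number from compound 3 to compound 4 (0.24 log units; within the scatter).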

Compound 4, half-maximal inhibitory concentration: 12 nM
The estimate for compound 4 lay 42-fold (1.62 log units) above the measured number; the whole stated range lies above it.
By their numbers in this assay, from the lowest: compound 4; then compounds 2, 1 and 3 (each within the scatter of the next, the first and the last beyond it).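

In this assay, the group on the carbonyl carbon proves far more influential than the earlier chain changes suggested: methylamino in place of isopropoxy gives the step (a 24-fold lower number from compound 3 to compound 4 (1.38 log units; beyond the scatter)), and the comparisons with the other two chains give (a 12-fold lower number from compound 2 to compound 4 (1.07 log units; beyond the scatter)) and (a 17-fold lower number from compound 1 to compound 4 (1.22 log units; beyond the scatter)). All three steps are large, whereas the steps among the isopropoxy, butoxy and pentyloxy compounds lie within the scatter or are modest, so the apparent tolerance held only while the change stayed in the chain on the oxygen. No supporting measurement is available to account for this gain.

Compound 4 differs from the other compounds in both the atom on the carbonyl carbon and the size of the group attached there, so the compounds shown do not separate these two changes; methoxy on the same carbon would test size with the oxygen kept, and ethylamino or a longer chain on the nitrogen would test size with the nitrogen kept. Dimethylamino would show whether the gain persists without the amide hydrogen, which remains open here.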